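The source may report more compounds than this note shows. Statements on the series, on what has been measured and on what is new or still open speak of the compounds shown alone.

Compounds measured so far:
compound 1, `CCSc1nc(=O)ccn1[C@@H]1O[C@H](COP(=O)(O)O)[C@@H](O)[C@H]1O`, gives 1500 nM in an in vitro functional assay on 1321-N1 cells for agonist activity at P2Y purinoceptor 2 (Homo sapiens), read by scintillation proximity assay and inositol phosphate accumulation; a lower number here means that less compound is needed, a higher number that more compound is needed for the effect.
compound 2, `O=c1[nH]c(=S)ccn1[C@@H]1O[C@H](COP(=O)(O)O)[C@@H](O)[C@H]1O`, reaches only the limit of this assay at > 100000 nM.
compound 3, `COc1nc(=O)ccn1[C@@H]1O[C@H](COP(=O)(O)OP(=O)(O)O)[C@@H](O)[C@H]1O`, gives 907 nM in this assay.

Among these, compound 1 has the highest of the two numbers that were read as values, and its nearest neighbour is compound 3, whose number differs from it by less than the usual scatter of repeated runs, so no order can be drawn between the two. Among the measured compounds shown here, compound 2 stands apart: its result is a limit, not a number, and it is the one value at the limit of > 100000 nM in this assay, at which 1 of the 3 values shown sits.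

The next compound, compound 4, `CNc1nc(=O)ccn1[C@@H]1O[C@H](COP(=O)(O)O)[C@@H](O)[C@H]1O`, differs from compound 1 in a single place: methylamino in place of ethylsulfanyl on an aromatic carbon. The rest of the shared core, including the sugar and the single phosphate, is unchanged.

For the measured compounds named here, with no measured pair that shows this kind of swap, the expectation rests only on the values above. Compound 4 is expected to stay close to compound 1 in this assay, with the step from compound 1 to compound 4 estimated at a 2.0-fold higher number from compound 1 to compound 4 (0.30 log units; within the scatter). The estimated value for compound 4 is 3000 nM, expected to fall between 600 nM and 15000 nM.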

Compound 4, half-maximal effective concentration: > 100000 nM
Compound 4: no number, only a limit; the forecaster's own chance of this, stated with the estimate: 15%; at least 33-fold (1.52 log units) between middle value and limit.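

In this assay, among the compounds shown here, methylamino in place of ethylsulfanyl on the aromatic carbon between two ring nitrogen atoms gives an at least 66-fold higher number from compound 1 to compound 4 (1.82 log units; beyond the scatter), the first step here between compounds that differ in one place. It shows that this position is sensitive to what it carries: a swap of one small, ring-free group for another, with the sugar and the single phosphate unchanged, is enough to take the compound from a measurable number to the end of the assay's range. The result for compound 4 is a limit and not a number, and it is now one of two such results in the set: the limit of > 100000 nM in this assay, at which 2 of the 4 values shown sit.

On these data alone, what stays open is which part of the swap matters, as the sulfur, the chain length and the added hydrogen-bond donor all change together in this one step. An ethylamino group would keep the chain of compound 1 while changing the linking atom, and a methylsulfanyl group would keep the sulfur with a shorter chain, so these two on the same core would begin to separate those features.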